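Compound 4: a ring nitrogen added at the amine end

The source may report more compounds than this note shows. Statements on the series, on what has been measured and on what is new or still open speak of the compounds shown alone.

In a functional assay on K562 cells (Homo sapiens) for inhibition, read by trypan blue exclusion, with a stated time of 72 h (a higher number here means a weaker inhibitor, a lower number a stronger inhibitor), compound 1 `Cn1c(=O)c(S(=O)(=O)c2ccc(Cl)cc2)cc2cnc(Nc3ccc4[nH]ccc4c3)nc21` gives 100 nM. Compound 2 `Cn1c(=O)c(S(=O)(=O)c2ccc(O)cc2)cc2cnc(Nc3ccc4[nH]ccc4c3)nc21` gives 100 nM, and no change at the digits printed from compound 1 to compound 2 (within the scatter). Compound 3 `Cn1c(=O)c(S(=O)(=O)Nc2ccc(F)cc2F)cc2cnc(Nc3ccc4[nH]ccc4c3)nc21` gives 5000 nM; a 50-fold higher number from compound 1 to compound 3 (1.70 log units; beyond the scatter), and likewise a 50-fold higher number from compound 2 to compound 3 (1.70 log units; beyond the scatter). Compound 1 therefore stands level with compound 2, the two together the lowest of the three numbers, with compound 3 furthest away.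

Compound 4 `Cn1c(=O)c(S(=O)(=O)c2ccc(Cl)cc2)cc2cnc(Nc3cnc4[nH]ccc4c3)nc21` departs from compound 1 at the opposite end of the shared core: a group of 9 heavy atoms (7 carbon, 2 nitrogen; one five-membered aromatic ring with 1 hetero atom, one six-membered aromatic ring with 1 hetero atom) in place of a group of 9 heavy atoms (8 carbon, 1 nitrogen; one five-membered aromatic ring with 1 hetero atom, one six-membered aromatic ring of carbon only), on a nitrogen on an aromatic ring. Among the measured compounds shown here, every measured step so far concerns the group on the sulfonyl sulfur, so none bears on this change, and the data give no direction for it. The expectation is a step within or near the scatter, a 1.2-fold higher number from compound 1 to compound 4 (0.08 log units; within the scatter). Compound 4 is estimated at 120 nM, with a range from 30 nM to 500 nM.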

Compound 4, half-maximal inhibitory concentration: 5000 nM
The estimate for compound 4 lay 42-fold (1.62 log units) below the measured number; measured number outside the range, above it.
By their numbers in this assay, from the lowest: compounds 1 and 2 (each within the scatter of the next); then compounds 3 and 4 (each within the scatter of the next).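

This end of the molecule is not tolerant of small edits: in this assay, the swap on the nitrogen gives a 50-fold higher number from compound 1 to compound 4 (1.70 log units; beyond the scatter), although it keeps the heavy-atom count and the hydrogen-bond donor count and adds only a hydrogen-bond acceptor. Until now, only the group on the sulfonyl sulfur had shown a large step. Nothing available accounts for this step.

Still open, as far as these compounds go, is whether a ring nitrogen elsewhere in the six-membered ring would carry the same penalty. Also open, from the compounds shown here alone, is how a phenyl bearing a morpholine would fare on this nitrogen.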